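The source may hold more compounds than are shown below. What is called first, only, known or untested is meant among the compounds shown, and "the series" means these compounds.

Working notes on the series. Among the compounds with values here, in a functional assay on MCF7 cells (Homo sapiens) for inhibition, read by MTT assay, with a stated time of 72 h (a lower number here means a stronger inhibitor, a higher number a weaker inhibitor), compound 1 (`Cc1ccc(C(C)C)c(OCc2cn(-c3ccccc3Cl)nn2)c1`) gives 15600 nM and compound 2 (`Cc1ccc(C(C)C)c(OCc2cn(-c3cccc(Cl)c3)nn2)c1`) gives 32100 nM, the higher of the two numbers so far. The next compound to read is compound 3 (`Cc1ccc(C(C)C)c(OCc2cn(-c3ccc(F)cc3)nn2)c1`), which carries 4-fluorophenyl in place of 3-chlorophenyl on an aromatic nitrogen. Within the data shown here, only one measured step bears on this change: a 2.1-fold higher number from compound 1 to compound 2 (0.31 log units; beyond the scatter). That step is modest, lies just beyond the scatter, and exchanges 2-chlorophenyl for 3-chlorophenyl. Among the measured compounds shown here, no measured compound carries 4-fluorophenyl, so the data give no firm direction. For the measured compounds named here, with a 2.1-fold higher number from compound 1 to compound 2 (0.31 log units; beyond the scatter) as the only guide, a step of similar or smaller size is expected in this assay, most likely none beyond the scatter. The expected step is a 1.3-fold lower number from compound 2 to compound 3 (0.11 log units; within the scatter). The estimate for compound 3 is 25000 nM, within a range of 11000 nM to 60000 nM.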

Compound 3, half-maximal inhibitory concentration: 22100 nM
Beside the measured number, compound 3's estimate is 1.1-fold (0.05 log units) above it, within the range that was stated.
By their numbers in this assay, from the lowest: compounds 1, 3 and 2 (each within the scatter of the next, the first and the last beyond it).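

In this assay, the change from 3-chlorophenyl to 4-fluorophenyl on the aromatic nitrogen gives a 1.5-fold lower number from compound 2 to compound 3 (0.16 log units; within the scatter), and the change from 2-chlorophenyl to 4-fluorophenyl gives a 1.4-fold higher number from compound 1 to compound 3 (0.15 log units; within the scatter). Compound 3 therefore cannot be separated from either chlorophenyl compound, so a fluorophenyl group at this position keeps the number in the same range, and only the two chlorophenyl compounds remain apart beyond the scatter. Nothing available bears on a cause for these small steps.

Still open, as far as these compounds go, is whether a phenyl ring carrying an amine or a carboxylic acid would move the number beyond the scatter. Also open, from the compounds shown here alone, is how 4-chlorophenyl would read, as it would separate the choice of halogen from its place on the ring.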